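Piperidinyl for tetrahydroisoquinolinyl on a second core

The compounds below may be only part of what the source reports. "The series", "measured", "known", "first", "only" and "open" are said of these compounds alone.

Measured compounds: compound 1 `CN(c1ccc(Oc2ncnc3sccc23)cc1)c1nccc(N2CCCCC2)n1`, 8790 nM; compound 2 `c1ccc2c(c1)CCN(c1ccnc(Nc3ccc(Oc4ncnc5ccsc45)cc3)n1)C2`, 17000 nM; compound 3 `CN(c1ccc(Oc2ncnc3sccc23)cc1)c1nccc(N2CCc3ccccc3C2)n1`, 6390 nM.

In a functional assay on A549 cells (Homo sapiens) for inhibition, read by MTT assay, with a stated time of 72 h (on this read-out lower numbers stand for stronger inhibition and higher numbers for weaker inhibition), compound 3 gives 6390 nM and compound 1 gives 8790 nM. The change piperidin-1-yl in place of 1,2,3,4-tetrahydroisoquinolin-2-yl on an aromatic carbon made a step of a 1.4-fold higher number from compound 3 to compound 1 (0.14 log units; within the scatter). Compound 2 gives 17000 nM in this assay, a higher number than compound 3; the difference between the two cores is not broken down here. Compound 4 `c1cc(N2CCCCC2)nc(Nc2ccc(Oc3ncnc4ccsc34)cc2)n1` differs from compound 2 by the same change, (piperidin-1-yl in place of 1,2,3,4-tetrahydroisoquinolin-2-yl on an aromatic carbon). Because the step of a 1.4-fold higher number from compound 3 to compound 1 (0.14 log units; within the scatter) was small, a step of similar size is expected from compound 2 to compound 4, a 1.3-fold higher number from compound 2 to compound 4 (0.11 log units; within the scatter). Compound 4 is therefore estimated at 22000 nM in this assay, expected to lie between 9000 nM and 55000 nM.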

Compound 4, half-maximal inhibitory concentration: 7800 nM
Beside the measured number, compound 4's estimate is 2.8-fold (0.45 log units) above it; measured number below the stated range.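

In this assay, putting piperidin-1-yl in place of 1,2,3,4-tetrahydroisoquinolin-2-yl on the core of compound 2 gave a 2.2-fold lower number from compound 2 to compound 4 (0.34 log units; beyond the scatter). The effect of this change was therefore not the same on the two cores: the same change on two cores in this assay, a 1.4-fold higher number (0.14 log units; within the scatter) from compound 3 to compound 1 and a 2.2-fold lower number (0.34 log units; beyond the scatter) from compound 2 to compound 4, 3.0-fold (0.48 log units) apart, beyond the scatter of two such steps

Among the compounds shown here, this rests on only two matched pairs, and it shows neither which difference between the cores is responsible nor how the change would behave on any further core. The compounds shown leave open whether a morpholin-4-yl group or an open-chain dimethylamino group in the same place would also give different steps on the two cores.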